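Vinyl in place of fluoro on the para-substituted phenyl ring

The compounds below may be only part of what the source reports. "The series", "measured", "known", "first", "only" and "open" are said of these compounds alone.

Measured compounds:
- Compound 1, `COc1cc(-c2ccnc3cc(-c4ccc5cc[nH]c5c4)nn23)cc(OC)c1OC`: 170 nM
- Compound 2, `COc1cc(-c2ccnc3cc(-c4ccc(-c5cnn(C)c5)cc4)nn23)cc(OC)c1OC`: 1150 nM
- Compound 3, `COc1cc(-c2ccnc3cc(-c4ccc(F)cc4)nn23)cc(OC)c1OC`: 3800 nM

In a functional assay on A549 cells (Homo sapiens) for inhibition, read by CCK-8 assay, with a stated time of 48 h (a lower number here means a stronger inhibitor, a higher number a weaker inhibitor), compound 3 gives the highest number of the three. Its nearest neighbour is compound 2, which lies a 3.3-fold higher number from compound 2 to compound 3 (0.52 log units; beyond the scatter) below it, while compound 1 lies further away, at a 22-fold higher number from compound 1 to compound 3 (1.35 log units; beyond the scatter). Both steps are beyond the scatter, and both replace the fluoro of compound 3 with a larger ring-bearing group.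

Compound 4, `C=Cc1ccc(-c2cc3nccc(-c4cc(OC)c(OC)c(OC)c4)n3n2)cc1`, has not yet been measured. It differs from compound 3 in one place: vinyl in place of fluoro on an aromatic carbon. Going by the values given here, the step that bears most directly on it is the one from compound 2 to compound 3, where a fluoro in place of 1-methyl-1H-pyrazol-4-yl gave a 3.3-fold higher number from compound 2 to compound 3 (0.52 log units; beyond the scatter). Vinyl is a much smaller group than that pyrazolyl and carries no ring, so the step back is expected to be smaller. Compound 4 is therefore expected to give 2200 nM in this assay, within a range of 800 nM to 6000 nM, a change of a 1.7-fold lower number from compound 3 to compound 4 (0.24 log units; within the scatter) that may or may not clear the scatter.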

Compound 4, half-maximal inhibitory concentration: 1030 nM
Estimate against measurement, compound 4: 2.1-fold (0.33 log units) above; measured number inside the range.
By their numbers in this assay, from the lowest: compound 1; then compounds 4 and 2 (each within the scatter of the next); then compound 3.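

In this assay, vinyl in place of fluoro gives a 3.7-fold lower number from compound 3 to compound 4 (0.57 log units; beyond the scatter), so at this place a group with no ring can already move the number beyond the scatter. The step of a 1.1-fold lower number from compound 2 to compound 4 (0.05 log units; within the scatter) lies within the scatter, so vinyl and 1-methyl-1H-pyrazol-4-yl cannot be told apart here, and the ring of the latter is not required to reach this level. Even so, the step of a 6.1-fold higher number from compound 1 to compound 4 (0.78 log units; beyond the scatter) shows that 4-vinylphenyl does not match 1H-indol-6-yl, a gap beyond the scatter.

From the compounds shown here alone, it remains open whether the double bond of vinyl matters, which an ethyl group at this place would test, and how an amine there would compare. Nothing measured here speaks to the cause of these differences.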